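Shrinking the Acyl Cap from Chlorophenyl to Methyl

This account rests on a few compounds, and the source may have more. Where it says the series, first, only, none or still open, it means among the compounds named here.

Two compounds share a core in which an amide-type nitrogen in a ring carries an acyl group. Compound 1 `CCCCCCCCC(=O)N1c2ccccc2CCC1C(=O)Nc1ccccc1C(F)(F)F` bears an octyl chain on that carbonyl carbon, and in a functional assay on PC-3 cells (Homo sapiens) for cytotoxicity, read by sulforhodamine B assay, with a stated time of 72 h (on this read-out lower numbers stand for stronger inhibition of growth and higher numbers for weaker inhibition of growth), compound 1 gives 4320 nM. Among the measured compounds shown here, compound 2 `O=C(Nc1ccccc1C(F)(F)F)C1CCc2ccccc2N1C(=O)c1ccc(Cl)cc1` carries a 4-chlorophenyl group in that place, and in this assay compound 2 gives 786 nM, the lowest of the two numbers measured so far. For the measured compounds named here, the only measured step so far is a 5.5-fold lower number from compound 1 to compound 2 (0.74 log units; beyond the scatter). Compound 3 `CC(=O)N1c2ccccc2CCC1C(=O)Nc1ccccc1C(F)(F)F` is the next variant: methyl in place of 4-chlorophenyl on a carbonyl carbon. Going by the values given here, only that single step bears on this change, and it showed that an alkyl chain in place of the chlorinated ring went with a clearly higher number. Methyl is a far shorter chain than octyl, so a move back toward the weaker end of the range is expected, with no firmer guide available. The expected step is a 6.4-fold higher number from compound 2 to compound 3 (0.80 log units; beyond the scatter). For compound 3 the estimate in this assay is 5000 nM, with a range from 1500 nM to 16000 nM.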

Compound 3, concentration for 50% growth inhibition: > 80000 nM
Compound 3: no number, only a limit (the forecaster's own chance of this, stated with the estimate: 15%); middle value at least 16-fold (1.20 log units) from the limit.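

In this assay compound 3 stands at a limit of the assay and not at a number: the limit of > 80000 nM in this assay, at which 1 of the 3 values shown sits.

This position on the carbonyl carbon therefore tolerates much less change than the first comparison alone could show: methyl in place of 4-chlorophenyl gives an at least 100-fold higher number from compound 2 to compound 3 (2.00 log units; beyond the scatter). The alkyl group itself also counts, as cutting the octyl chain down to methyl gives an at least 18-fold higher number from compound 1 to compound 3 (1.26 log units; beyond the scatter), so the earlier contrast between a chain and a chlorinated ring was not the whole story, and a long chain and a bare methyl cannot be treated as one kind of group here.

The compounds shown leave open how growth inhibition changes along the way from methyl to octyl, which a butyl or hexyl chain would help to trace. They also leave open whether the ring or its chlorine accounts for the low number of compound 2, a question that a plain phenyl group, or a 4-fluorophenyl group, in the same place would address.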